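Removing the isobutyl from compound 2

The compounds below may be only part of what the source reports. "The series", "measured", "known", "first", "only" and "open" are said of these compounds alone.

For the measured compounds named here, compound 2 `CC(C)C[C@H](NC(=O)c1ccc(C(=O)Nc2ccc3c(c2)C(C)(C)CCC3(C)C)cc1)C(=O)OCc1c(-c2ccccc2)no[n+]1[O-]` gives 970 nM in a functional assay on NB-4 cells (Homo sapiens) for antiproliferative activity, read by MTT assay, with a stated time of 48 h (a lower number here means a stronger inhibitor, a higher number a weaker inhibitor), the lower of the two numbers measured so far. Compound 1 `CC1(C)CCC(C)(C)c2cc(NC(=O)c3ccc(C(=O)OCCCOC(=O)c4ccc(OCc5c(-c6ccccc6)no[n+]5[O-])cc4)cc3)ccc21` gives 140000 nM in this assay, a gap beyond the usual scatter. Compound 3 `CC1(C)CCC(C)(C)c2cc(NC(=O)c3ccc(C(=O)NCC(=O)OCc4c(-c5ccccc5)no[n+]4[O-])cc3)ccc21` is not yet measured; it differs from compound 2 by hydrogen in place of isobutyl on a saturated chain carbon bound to an amide-type nitrogen and a carbonyl carbon. Going by the values given here, no step of this kind has been measured, so its size rests on judgement alone. A mild weakening, not far beyond the scatter, is expected rather than a gain. The expected step is a 2.1-fold higher number from compound 2 to compound 3 (0.31 log units; beyond the scatter). Compound 3 is estimated at 2000 nM, with a range from 600 nM to 7000 nM.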

Compound 3, half-maximal inhibitory concentration: 190 nM
Compound 3: the middle estimate sits 11-fold (1.02 log units) above what was measured; the measured number lies below the stated range.
By their numbers in this assay, from the lowest: compound 3; then compound 2; then compound 1.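

At this saturated chain carbon bound to an amide-type nitrogen and a carbonyl carbon, the isobutyl is not required for activity in this assay: hydrogen in place of isobutyl gives a 5.1-fold lower number from compound 2 to compound 3 (0.71 log units; beyond the scatter), a step beyond the scatter. At this place the isobutyl therefore costs activity rather than adding to it. No evidence is available to explain this step.

From the compounds shown here alone, it remains open whether a methyl would fall between hydrogen and isobutyl at this carbon. Also open, going by these compounds, is how a longer chain ending in an amine or a carboxylic acid would read there.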